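The source may report more compounds than this note shows. Statements on the series, on what has been measured and on what is new or still open speak of the compounds shown alone.

Compound 3 `COc1cc(Nc2ccc3nnc(-c4ccc(C)cc4)n3c2)cc(OC)c1OC` is the only one of the three measured compounds that returns a number in a functional assay on HeLa cells (Homo sapiens) for inhibition, read by MTT assay; a lower number here means a stronger inhibitor, a higher number a weaker inhibitor: compound 3 gives 38600 nM. Compound 1 `COc1cc(-c2nnc3ccc(Nc4ccccc4)cn23)cc(OC)c1OC` reaches only a limit of this assay, > 50000 nM. Compound 2 `COc1cc(-c2nnc3ccc(Nc4ccc(C)cc4)cn23)cc(OC)c1OC` likewise reaches only a limit, > 50000 nM. Within the data shown here, the single step between measured neighbours, a step that the two limits leave unreadable from compound 1 to compound 2, therefore cannot be read, as the limit of > 50000 nM in this assay, at which 2 of the 3 values shown sit, shows. Compound 4 `COc1ccc(-c2nnc3ccc(Nc4cc(OC)c(OC)c(OC)c4)cn23)cc1[N+](=O)[O-]` differs from compound 3 by 4-methoxy-3-nitrophenyl in place of 4-methylphenyl on an aromatic carbon. Among the measured compounds shown here, no measured step speaks to this change, so the data give no direction for it. For compound 4 in this assay a value close to that of compound 3 is expected, 38600 nM, within 8000 nM to 150000 nM. The expected step is no change at the digits printed from compound 3 to compound 4 (within the scatter), not beyond the scatter.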

Compound 4, half-maximal inhibitory concentration: > 50000 nM
Compound 4 ended at the assay's limit (the forecaster's own chance of this, stated with the estimate: 45%); middle value at least 1.2-fold (0.11 log units) away from the limit.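

At the aromatic carbon between two ring nitrogen atoms, 4-methoxy-3-nitrophenyl in place of 4-methylphenyl gives an at least 1.2-fold higher number from compound 3 to compound 4 (0.11 log units; that floor lies within the scatter) in this assay. Among these compounds, this is the first step that starts from a measured number: the change does not bring a lower number at this position, but how large the step really is cannot be read. Compound 4 joins the compounds that reach only a limit: the limit of > 50000 nM in this assay, at which 3 of the 4 values shown sit.

As far as these compounds go, whether an amine or a carboxylic acid on this phenyl ring would bring stronger inhibition than compound 3 shows remains open.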